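Swapping phenyl for pyridin-4-yl: what to expect

The source may hold more compounds than are shown below. What is called first, only, known or untested is meant among the compounds shown, and "the series" means these compounds.

- Compound 1 `C[C@H]1CN([C@@H](C)CO)C(=O)c2cccc(NC(=O)c3ccncc3)c2O[C@@H]1CN(C)Cc1ccc(Cl)c(Cl)c1`: 64000 nM
- Compound 2 `C[C@H]1CN([C@@H](C)CO)C(=O)c2cccc(NC(=O)c3ccncc3)c2O[C@@H]1CN(C)Cc1ccccc1`: 100000 nM

In a physicochemical assay for solubility, in phosphate buffer (on this read-out higher numbers stand for higher solubility and lower numbers for lower solubility), compound 2 gives 100000 nM, which lies within the scatter of compound 1 at 64000 nM. Among the compounds with values here, only two numbers exist so far, and they cannot be told apart.

Compound 3 `C[C@H]1CN([C@@H](C)CO)C(=O)c2cccc(NC(=O)c3ccncc3)c2O[C@@H]1CN(C)Cc1ccncc1` has pyridin-4-yl in place of phenyl on a saturated chain carbon bound to an amine nitrogen. Just one measured step touches this place: a 1.6-fold higher number from compound 1 to compound 2 (0.19 log units; within the scatter). Within the data shown here, that step swapped a different group, and no measured compound yet carries pyridin-4-yl there, so it is only a weak guide. It does show that one change at this place stayed within the scatter, and the same is expected here, with no clear direction in this assay. The expected size is a 1.2-fold higher number from compound 2 to compound 3 (0.08 log units; within the scatter). For compound 3 the estimated value is 120000 nM, with an expected range from 60000 nM to 250000 nM.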

Compound 3, solubility: 100000 nM
Beside the measured number, compound 3's estimate is 1.2-fold (0.08 log units) above it, within the range that was stated.
By their numbers in this assay, from the lowest: compounds 1, 2 and 3 (each within the scatter of the next).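

Putting pyridin-4-yl in place of phenyl on a saturated chain carbon bound to an amine nitrogen gives no change at the digits printed from compound 2 to compound 3 (within the scatter) in this assay, and putting it in place of 3,4-dichlorophenyl gives a 1.6-fold higher number from compound 1 to compound 3 (0.19 log units; within the scatter). Within the data shown here, this is the first measured case with a nitrogen in this aromatic ring, which brings in a hydrogen-bond acceptor, and all three rings now tested at this place remain within the scatter of one another. No measurement here offers an explanation for this result.

As far as these compounds go, it remains open whether a carboxylic acid or an amine on this ring, or a simple alkyl chain in place of the ring, would also stay within the scatter. These three compounds also say nothing about how pyridin-4-yl behaves on any other read-out.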